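Chloro in place of dimethylamino: cytotoxicity notes

The compounds below may be only part of what the source reports. "The series", "measured", "known", "first", "only" and "open" are said of these compounds alone.

compound 1 `Cc1cc(NC(=O)Nc2ccc(F)cc2)c2ccccc2n1` gives > 25000 nM
compound 2 `Cc1cc(NC(=O)Nc2cccc(N(C)C)c2)c2ccccc2n1` gives > 25000 nM

In an ADME assay on BJ cells (Homo sapiens) for cytotoxicity, with a stated time of 72 h (on this read-out higher numbers stand for an effect only at larger amounts of compound and lower numbers for an effect already at smaller amounts), compound 2 gives > 25000 nM as a limit and not a number. Compound 1 gives > 25000 nM as a limit too. Compound 3 `Cc1cc(NC(=O)Nc2cccc(Cl)c2)c2ccccc2n1` carries chloro in place of dimethylamino on an aromatic carbon, meta to a large group chloro in place of dimethylamino on an aromatic carbon in an otherwise unchanged structure. No measured step sizes this change, so no shift beyond the usual scatter is expected, and another limit is the likeliest report. The expected step that the limit leaves unreadable from compound 2 to compound 3 remains only an estimate. For compound 3 the estimate is 30000 nM with an expected range from 12000 nM to 60000 nM in this assay for now.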

Compound 3, half-maximal effective concentration: > 25000 nM
Compound 3 ended at the assay's limit; the forecaster's own chance of this, stated with the estimate: 80%; the middle value does not contradict the limit.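

No step can be read from compound 2 to compound 3 or from compound 1 to compound 3 in this assay, because all the values rest on one limit: the limit of > 25000 nM in this assay, at which 3 of the 3 values shown sit. As far as these compounds go, the concentration at which compound 1, compound 2 or compound 3 becomes cytotoxic stays open.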